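The source may hold more compounds than are shown below. What is called first, only, known or untested is meant among the compounds shown, and "the series" means these compounds.

Measured compounds in an ADME assay on L02 cells (Homo sapiens) for antiproliferative activity, read by MTT assay, with a stated time of 48 h; on this read-out higher numbers stand for weaker inhibition and lower numbers for stronger inhibition:
- compound 1 `Cc1ccccc1-n1nncc1CN1C(=O)C2(C(C#N)=C(N)Oc3c2c2nc4ccccc4nc2c2ccccc32)c2ccccc21` sits at a limit, > 50000 nM
- compound 2 `N#CC1=C(N)Oc2c(c3nc4ccccc4nc3c3ccccc23)C12C(=O)N(Cc1cnnn1-c1cccc(Cl)c1)c1ccccc12` gives 35200 nM
- compound 3 `N#CC1=C(N)Oc2c(c3nc4ccccc4nc3c3ccccc23)C12C(=O)N(Cc1cnnn1-c1cccc(S(N)(=O)=O)c1)c1ccccc12` sits at a limit, > 50000 nM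

Compound 3 therefore stands at the limit of this assay, not at a number; the same holds for compound 1, and only compound 2 returns a number. Two of the three values share this limit (the limit of > 50000 nM in this assay, at which 2 of the 3 values shown sit).

The step to the unmeasured compound 4 `Cc1ccc(-n2nncc2CN2C(=O)C3(C(C#N)=C(N)Oc4c3c3nc5ccccc5nc3c3ccccc43)c3ccccc32)c(C)c1` is 2,4-dimethylphenyl in place of 3-sulfamoylphenyl on an aromatic nitrogen. Going by the values given here, the measured steps that bear on it are an at least 1.4-fold higher number from compound 2 to compound 3 (0.15 log units; that floor lies within the scatter), a step that the two limits leave unreadable from compound 1 to compound 3 and an at least 1.4-fold lower number from compound 1 to compound 2 (0.15 log units; that floor lies within the scatter); none of them resolves a size beyond the scatter, and the exchange that brings a limit back to a number is the one from compound 1 to compound 2. Compound 1, which carries 2-methylphenyl on the same aromatic nitrogen and is the nearest measured analogue of compound 4, sits at the limit. No step beyond the scatter is therefore expected in this assay from compound 3 to compound 4, and the result is expected to be a limit again more often than a number, the estimated step being a number no higher from compound 3 to compound 4 (the limit leaves the size open).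

Compound 4 is estimated at 50000 nM, with an expected range from 30000 nM to 100000 nM.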

Compound 4, half-maximal inhibitory concentration: > 50000 nM
Compound 4 gave a limit, no number (the forecaster's own chance of this, stated with the estimate: 70%); the middle value lies on the limit itself.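

On the aromatic nitrogen of the five-membered ring, the all-carbon 2,4-dimethylphenyl of compound 4 ends at the same limit as the 3-sulfamoylphenyl of compound 3, so this assay does not tell these two groups apart. The exchange of 3-chlorophenyl for 2,4-dimethylphenyl gives an at least 1.4-fold higher number from compound 2 to compound 4 (0.15 log units; that floor lies within the scatter); the other two new steps cannot be read, both ends of each being limits. Compound 2 remains the only compound with a number, and the limit now holds the other three: the limit of > 50000 nM in this assay, at which 3 of the 4 values shown sit.

Going by these compounds, the order among compound 1, compound 3 and compound 4 stays hidden behind the limit, and it remains open whether the number of compound 2 belongs to the chloro group itself or to the 3-chlorophenyl as a whole. Also open, on these data alone, is how this assay responds when the same aromatic nitrogen carries a phenyl bearing an amine or a carboxylic acid, or a longer chain in place of the aromatic ring.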